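This account rests on a few compounds, and the source may have more. Where it says the series, first, only, none or still open, it means among the compounds named here.

Among the measured compounds shown here, of the two compounds with a number so far in a functional assay on HL-60 cells (Homo sapiens) for inhibition, read by MTT assay, with a stated time of 72 h, tested at 30 uM (a lower number here means less inhibition of growth, a higher number more inhibition of growth at the concentration tested), compound 1 (`C=CCc1cc(O)c(O)c(CN2CCC(CCO)CC2)c1`) gives 39.4% and compound 2 (`C=CCc1ccc(OCc2cn(-c3cc(OC)c(OC)c(OC)c3)nn2)c(O)c1`) gives 32.8% at the single concentration tested. These two values lie within the scatter of each other, so compound 1 cannot be ranked against compound 2.

Compound 3 (`C=CCc1cc(O)c(O)c(CN2CCC(Cc3ccccc3)CC2)c1`) keeps the core of compound 1 and differs in one place. It carries phenyl in place of hydroxymethyl on a saturated chain carbon bound to a saturated ring carbon, which turns 2-hydroxyethyl into benzyl. For the measured compounds named here, no measured pair shows what a swap of this kind does, so what follows is a judgement and not a reading of a trend. Compound 1 at 39.4% leaves plenty of room upward on this scale, and a moderate rise in inhibition, beyond the scatter, is expected. The estimated step is a number 18.6 percentage points higher from compound 1 to compound 3 (beyond the scatter) and it carries wide uncertainty. In this assay compound 3 is expected to give 58% with an estimated range from 35% to 85% as the likely span of the result.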

Compound 3, percent growth inhibition at one concentration: 90.6%
Beside the measured number, compound 3's estimate is 32.6 percentage points below it; measured number outside the range, above it.
By their numbers in this assay, from the lowest: compounds 2 and 1 (each within the scatter of the next); then compound 3.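

Among the compounds shown here, until now no pair of compounds showed whether this part of the structure matters. The change from 2-hydroxyethyl to benzyl, on a saturated chain carbon bound to a saturated ring carbon, gives a number 51.2 percentage points higher from compound 1 to compound 3 (beyond the scatter) in this assay, so the group at this place has a large bearing on growth inhibition at the concentration tested. The swap changes several things at once: phenyl brings one six-membered aromatic ring of carbon only, while the hydroxymethyl that leaves takes a hydrogen-bond donor and a hydrogen-bond acceptor with it, and nothing available explains the step or separates these changes.

As far as these compounds go, it remains open whether the aromatic ring itself matters or whether a saturated carbon ring such as cyclohexyl would serve as well, and whether a chlorine on the phenyl would shift the number further. From the compounds shown here alone, it is equally open how an amine or a carboxylic acid at the end of this group, or a longer chain leading to the phenyl, would read in this assay.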